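From Allyl to Benzyl on the Nitrogen Chain

The compounds below may be only part of what the source reports. "The series", "measured", "known", "first", "only" and "open" are said of these compounds alone.

Measured so far in a functional assay on BV-2 cells (Mus musculus) for inhibition, read by Griess assay, with a stated time of 24 h; a higher number here means a weaker inhibitor, a lower number a stronger inhibitor:
Compound 1 `Oc1ccc(Br)cc1-c1ccn(Cc2ccccc2)n1` gives a limit (> 200000 nM)
Compound 2 `C=CCc1ccc(O)c(-c2ccn(CC=C)n2)c1` gives a number (1200 nM)

The entry for compound 1 is a limit of this assay and not a number. For the measured compounds named here, that leaves compound 2 (1200 nM) as the only compound with a true number, and so the sole numerical reference point for what follows.

Compound 3 `C=CCc1ccc(O)c(-c2ccn(Cc3ccccc3)n2)c1` has not yet been measured. It departs from compound 2 in one place, with phenyl in place of vinyl on a saturated chain carbon bound to an aromatic nitrogen. The same difference, cut one bond further out, reads allyl to benzyl.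

Going by the values given here, no measured step shows directly what this change does. Compound 1 also carries a benzyl group, and its entry (> 200000 nM) is a limit. On that basis, a moderate loss of inhibition is expected rather than a collapse, and the estimate is a 2.5-fold higher number from compound 2 to compound 3 (0.40 log units; beyond the scatter) in this assay. Compound 3 is estimated at 3000 nM (expected range 600 nM to 25000 nM).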

Compound 3, half-maximal inhibitory concentration: 92500 nM
Estimate against measurement, compound 3: 31-fold (1.49 log units) below, outside the stated range (above it).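

In this assay, the change from allyl to benzyl on the saturated chain carbon bound to an aromatic nitrogen now has a measured size (a 77-fold higher number from compound 2 to compound 3 (1.89 log units; beyond the scatter)), showing that inhibition depends strongly on the group at this place and that this change costs far more than a moderate loss. With benzyl held constant, a second place also proves to matter, as allyl in place of bromo on an aromatic carbon brings the number down (an at least 2.1-fold lower number from compound 1 to compound 3 (0.33 log units; beyond the scatter)), yet this gain leaves compound 3 much weaker than compound 2. Compound 1 stands at a limit of the assay and not at a number, so this second step is only a bound: the limit of > 200000 nM in this assay, at which 1 of the 3 values shown sits.

The compounds shown leave open whether the loss follows the phenyl ring itself or simply a larger group on the nitrogen, a question that a saturated propyl chain or a cyclohexylmethyl group in the same place would help to separate. On these data alone, they also give no cause for the loss, and it remains open whether a benzyl ring carrying an amine or a carboxylic acid would regain any inhibition.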